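This account rests on a few compounds, and the source may have more. Where it says the series, first, only, none or still open, it means among the compounds named here.

In a functional assay on SK-OV-3 cells (Homo sapiens) for antiproliferative activity, read by MTT assay, with a stated time of 72 h (a higher number here means a weaker inhibitor, a lower number a stronger inhibitor), compound 1 `O=C(CCc1cccc2c1B(O)OC2)Nc1ccccc1` gives 200 nM. Compound 2 `COc1ccc(-c2cccc(NC(=O)CCc3cccc4c3B(O)OC4)c2)cc1` carries a 4-methoxyphenyl group in place of a hydrogen on an aromatic carbon and gives 48 nM. Compound 3 `CSc1ccc(-c2cccc(NC(=O)CCc3cccc4c3B(O)OC4)c2)cc1` carries a 4-(methylsulfanyl)phenyl group instead and gives 140 nM. Adding that group changes little, with a 1.4-fold lower number from compound 1 to compound 3 (0.15 log units; within the scatter), so compound 3 stands level with compound 1 within the scatter. Compound 2 is the strongest of the three, with a 4.2-fold lower number from compound 1 to compound 2 (0.62 log units; beyond the scatter) and a 2.9-fold higher number from compound 2 to compound 3 (0.46 log units; beyond the scatter).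

Compound 4 `O=C(CCc1cccc2c1B(O)OC2)Nc1cccc(-c2ccc(C(F)(F)F)cc2)c1` has trifluoromethyl in place of methylsulfanyl on an aromatic carbon, para to a large group (trifluoromethyl in place of methylsulfanyl on an aromatic carbon). Among the compounds with values here, the closest precedent is the swap at the same place between methoxy and methylsulfanyl, a 2.9-fold higher number from compound 2 to compound 3 (0.46 log units; beyond the scatter), a modest step showing that this group can move the number in this assay. Within the data shown here, the additions to compound 1 suggest that the outcome depends on the group, yet no measured compound carries trifluoromethyl, so the direction remains open. No step beyond the scatter is therefore expected, although a modest one either way would not surprise. The expected change is a 1.3-fold lower number from compound 3 to compound 4 (0.10 log units; within the scatter). For compound 4 the estimated value is 110 nM, within a range of 40 nM to 300 nM.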

Compound 4, half-maximal inhibitory concentration: 500 nM
For compound 4 the middle estimate is 4.5-fold (0.66 log units) below the measured one; measured number outside the range, above it.
By their numbers in this assay, from the lowest: compound 2; then compounds 3 and 1 (each within the scatter of the next); then compound 4.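

In this assay this position can do more than lower the number or leave it level, as the earlier additions to compound 1 did: with trifluoromethyl in place, adding the 4-substituted phenyl now gives a 2.5-fold higher number from compound 1 to compound 4 (0.40 log units; beyond the scatter). The direct swap from methylsulfanyl gives a 3.6-fold higher number from compound 3 to compound 4 (0.55 log units; beyond the scatter) and shows that a change of one group at this position can weaken the compound even where the swap between methoxy and methylsulfanyl had already moved the number in the same direction. The swap from methoxy gives a 10-fold higher number from compound 2 to compound 4 (1.02 log units; beyond the scatter), the only large step in this set, so the choice of group at this one position spans the widest gap seen here, and no measurement shown here bears on what lies behind it.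

Three groups at this position are too few to give a rule for which groups lower the number and which raise it. On these data alone, whether an amine, a carboxylic acid or a longer chain such as ethoxy would fall below compound 2 or land above compound 4 stays open.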